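Adding a methoxy group on the outer ring of compound 2

The compounds below may be only part of what the source reports. "The series", "measured", "known", "first", "only" and "open" are said of these compounds alone.

Measured compounds:
- compound 1, `COc1ccc2[nH]c(-c3nc(-c4ccccc4)no3)cc2c1`, gives 18700 nM
- compound 2, `Fc1ccc2[nH]c(-c3nc(-c4ccccc4)no3)cc2c1`, gives 10800 nM
- compound 3, `O=[N+]([O-])c1ccc2[nH]c(-c3nc(-c4ccccc4)no3)cc2c1`, gives 12500 nM

In a functional assay on COLO 320 cells (Homo sapiens) for antiproliferative activity, read by WST assay, with a stated time of 72 h (a lower number here means a stronger inhibitor, a higher number a weaker inhibitor), compound 2 gives the lowest of the three numbers, though none of the three is separated from another beyond the scatter: the step of a 1.7-fold lower number from compound 1 to compound 2 (0.24 log units; within the scatter) and the step of a 1.2-fold higher number from compound 2 to compound 3 (0.06 log units; within the scatter) both stay within it, as does a 1.5-fold lower number from compound 1 to compound 3 (0.17 log units; within the scatter). The three compounds thus behave alike in this assay, and compound 2 is not to be called the strongest.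

Compound 4, `COc1ccc(-c2noc(-c3cc4cc(F)ccc4[nH]3)n2)cc1`, differs from compound 2 by methoxy in place of hydrogen on an aromatic carbon. Every measured step changes a group on the core of compound 2; none of them touches the six-membered aromatic ring of carbon only where the new methoxy sits. The steps that are known are therefore only loosely related, and all of them were small, within the scatter. On that basis the expectation for compound 4 is a step of a 1.0-fold higher number from compound 2 to compound 4 (0.01 log units; within the scatter), not beyond the scatter, in no particular direction. The estimate for compound 4 in this assay is 11000 nM, with a range from 4000 nM to 30000 nM.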

Compound 4, half-maximal inhibitory concentration: 14800 nM
The estimate for compound 4 lay 1.3-fold (0.13 log units) below the measured number; the measured number falls inside the stated range.
By their numbers in this assay, from the lowest: compounds 2, 3, 4 and 1 (each within the scatter of the next).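

In this assay, for the compounds shown here, methoxy in place of hydrogen on an aromatic carbon of the six-membered aromatic ring of carbon only, para to a large group, gives a 1.4-fold higher number from compound 2 to compound 4 (0.14 log units; within the scatter), and this is the first measured change on that ring, since the earlier steps all changed a group on the core. Going by these compounds alone, the result shows that this position accepts methoxy without a shift beyond the scatter, so the small size of the earlier steps now extends to a second part of the molecule, although only for this one group on the fluoro-substituted core. No measurement shown here bears on why the step is this small.

The compounds shown leave open whether an amine, a carboxylic acid or a longer chain such as butoxy at the same position would move the number beyond the scatter, or whether this position matters at all for the activity seen. They also leave open whether methoxy on this ring would give a similarly small step on the core of compound 1 or of compound 3, which carry methoxy and nitro in place of fluoro.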